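Pyrazole attachment point in a shared urea-amide core

This account rests on a few compounds, and the source may have more. Where it says the series, first, only, none or still open, it means among the compounds named here.

Measured so far in a functional assay on MV4-11 cells (Homo sapiens) for antiproliferative activity, with a stated time of 6 days, tested at 6.25 uM; a lower number here means a weaker effect, a higher number a stronger effect of the compound at the concentration tested:
- compound 1, `CNC(=O)N1CCCc2ccc(NC(=O)c3ccc(-c4cc[nH]n4)cc3)cc21`: 99.1%
- compound 2, `CNC(=O)N1CCCc2ccc(NC(=O)c3cccc(-c4cnn(C)c4)c3)cc21`: 93.5%
- compound 3, `CNC(=O)N1CCCc2ccc(NC(=O)c3cccc(-c4cc[nH]n4)c3)cc21`: 89.7%

Compound 1 has the highest of the three numbers in this assay, yet its gaps to compound 2 and to compound 3 both lie within the scatter, so the three cannot be ranked. Compound 4, `CNC(=O)N1CCCc2ccc(NC(=O)c3ccc(-c4cn[nH]c4)cc3)cc21`, is built from the same atoms as compound 1, joined differently: 1H-pyrazol-4-yl in place of 1H-pyrazol-3-yl on an aromatic carbon. For the measured compounds named here, the only measured step that touches the pyrazole, a number 3.8 percentage points lower from compound 2 to compound 3 (within the scatter), also exchanged one pyrazole attachment for another, though at a different place on the core, and it stayed within the scatter. Going by the values given here, no measured pair shows exactly the change from compound 1 to compound 4, so the expectation rests on that single step. The step from compound 1 to compound 4 is therefore expected to be small, a number 4.1 percentage points lower from compound 1 to compound 4 (within the scatter), with no shift beyond the scatter. Compound 4 is estimated to give 95% in this assay, within a range from 85% to 100%.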

Compound 4, a percentage reported as inhibition, at one concentration (the size of the read-out at that concentration, not a potency): 98.3%
Compound 4: middle estimate off by 3.3 percentage points, on the low side; the range from low to high includes it.
By their numbers in this assay, from the lowest: compounds 3, 2, 4 and 1 (each within the scatter of the next).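

On the six-membered aromatic ring of carbon only, para to a large group, exchanging 1H-pyrazol-3-yl for 1H-pyrazol-4-yl gave, in this assay, a number 0.8 percentage points lower from compound 1 to compound 4 (within the scatter) and so did not separate the two attachments. Unlike the earlier step between compound 2 and compound 3, where a methyl group changed as well, this pair changes only the attachment of an unsubstituted pyrazole. No supporting measurement offers an explanation for this result.

The compounds shown leave open whether a group other than a pyrazole at this place, such as a carboxylic acid or an amine, would keep the number in the same range. Since the read-out comes from one concentration, they also leave open whether compound 1 and compound 4 differ in potency.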